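The source may hold more compounds than are shown below. What is called first, only, known or untested is meant among the compounds shown, and "the series" means these compounds.

In an ADME assay on J774 cells (Mus musculus) for cytotoxicity (a higher number here means that more compound is needed for the effect, a lower number that less compound is needed), compound 3 `CCCCc1cc2c(=O)c(C(=O)NCCO)c[nH]c2cc1OCCOc1ccccc1` gives > 20000 nM, which is a limit and not a number. Compound 1 `CCCCc1cc2c(=O)c(C#N)c[nH]c2cc1OCCOc1ccccc1` gives > 20000 nM, also a limit. Compound 2 `CCCCc1cc2c(=O)cc[nH]c2cc1OCCOc1ccccc1` gives > 20000 nM, again a limit.

The next compound, compound 4 `CCCCc1cc2c(=O)c(C(=O)NC(C)C)c[nH]c2cc1OCCOc1ccccc1`, keeps the shared core and changes one group, with isopropyl in place of 2-hydroxyethyl on an amide-type nitrogen. Within the data shown here, no measured step makes this same change, so the nearest guides are the three steps among the compounds already tested: a step that the two limits leave unreadable from compound 1 to compound 2, a step that the two limits leave unreadable from compound 1 to compound 3 and a step that the two limits leave unreadable from compound 2 to compound 3. None of them has a readable size. Even so, swapping the group on that aromatic carbon never brought a number into view in this assay.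

No step beyond the usual scatter, in either direction, is expected because the limit of > 20000 nM in this assay, at which 3 of the 3 values shown sit, is all that the measurements show. The estimated change is a number no higher from compound 3 to compound 4 (the limit leaves the size open). For compound 4, the expected value is 20000 nM, with an estimated range from 10000 nM to 40000 nM, and it may well be reported only as a limit.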

Compound 4, half-maximal effective concentration: > 20000 nM
Compound 4 was reported as a limit; the forecaster's own chance of this, stated with the estimate: 85%; the middle value lies on the limit itself.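

The steps from compound 1, compound 2 and compound 3 to compound 4 cannot be read, since each joins two limits. The compounds shown leave open how much of any of them is needed for an effect in this assay, and whether these group changes alter that amount.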